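Replacing the hydroxyl of compound 1 with a methoxy group

A few compounds are considered here, and "the series" means these few. Any claim that something is new, unique, unknown or untested is made for them only; others in the source may bear on it.

Values in a functional assay on PC-3 cells (Homo sapiens) for inhibition, with a stated time of 72 h; a higher number here means a weaker inhibitor, a lower number a stronger inhibitor:
- Compound 1 `Cc1nc(-c2nc[nH]n2)ccc1-c1cnc2c(n1)N([C@H]1CC[C@@H](O)CC1)C(=O)CN2` gives 37 nM
- Compound 2 `Cc1nc(-c2nc[nH]n2)ccc1-c1cnc2c(n1)N(CC1CCOCC1)C(=O)CN2` gives 82 nM
- Compound 3 `COCCN1C(=O)CNc2ncc(-c3ccc(-c4nc[nH]n4)nc3C)nc21` gives 137 nM

Compound 1 has the lowest number of the three. Compound 4 `CO[C@H]1CC[C@H](N2C(=O)CNc3ncc(-c4ccc(-c5nc[nH]n5)nc4C)nc32)CC1` changes it in one place: 4-methoxycyclohexyl in place of 4-hydroxycyclohexyl on an amide-type nitrogen in a ring. Going by the values given here, no measured step makes this exact change. Two measured steps do leave 4-hydroxycyclohexyl, and both end at a higher number: a 2.2-fold higher number from compound 1 to compound 2 (0.35 log units; beyond the scatter) and a 3.7-fold higher number from compound 1 to compound 3 (0.57 log units; beyond the scatter). Compound 4 keeps the carbon ring, unlike compound 2 and compound 3, so a smaller step in the same direction seems likely. For compound 4 the expected step in this assay is a 1.9-fold higher number from compound 1 to compound 4 (0.28 log units; within the scatter). Compound 4 is estimated at 70 nM, with an expected range from 30 nM to 160 nM.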

Compound 4, half-maximal inhibitory concentration: 38 nM
Beside the measured number, compound 4's estimate is 1.8-fold (0.27 log units) above it, within the range that was stated.
By their numbers in this assay, from the lowest: compounds 1 and 4 (each within the scatter of the next); then compounds 2 and 3 (each within the scatter of the next).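

With a 1.0-fold higher number from compound 1 to compound 4 (0.01 log units; within the scatter) in this assay the hydrogen-bond donor of 4-hydroxycyclohexyl goes without a readable change, so among these compounds the hydroxyl hydrogen is not needed at this position. With a 3.6-fold lower number from compound 3 to compound 4 (0.56 log units; beyond the scatter) and a 2.2-fold lower number from compound 2 to compound 4 (0.33 log units; beyond the scatter) compound 4 also stands apart from the two compounds without the carbon ring, so the gap seen earlier stays once the hydroxyl is gone and goes with the ring. No evidence is available that explains either result. From the compounds shown here alone, whether an amine, a carboxylic acid or a longer ether chain in place of the hydroxyl of 4-hydroxycyclohexyl would keep the number stays open.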